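The source may hold more compounds than are shown below. What is called first, only, known or untested is meant among the compounds shown, and "the series" means these compounds.

Compound 2 `COc1cc2c(Oc3ccc(NC(=O)c4cn(-c5cc(C)ccc5C)cn4)cc3F)ccnc2cc1OCCCN1CCN(C)CC1` is examined in a functional assay on MKN-45 cells (Homo sapiens) for cytotoxicity, read by MTT assay, with a stated time of 72 h (on this read-out lower numbers stand for stronger inhibition and higher numbers for weaker inhibition), where compound 2 gives 650 nM. Among the three measured compounds it stands second highest: compound 1 `COc1cc2c(Oc3ccc(NC(=O)c4cn(-c5ccccc5OC)cn4)cc3F)ccnc2cc1OCCCN1CCN(C)CC1` gives 220 nM, and compound 3 `COc1cc2c(Oc3ccc(NC(=O)c4cn(-c5ccc(Cl)cc5Cl)cn4)cc3F)ccnc2cc1OCCCN1CCN(C)CC1` gives 4840 nM. The step from compound 1 to compound 2 is a 3.0-fold higher number from compound 1 to compound 2 (0.47 log units; beyond the scatter), and the step from compound 2 to compound 3 is a 7.4-fold higher number from compound 2 to compound 3 (0.87 log units; beyond the scatter), with a 22-fold higher number from compound 1 to compound 3 (1.34 log units; beyond the scatter) from compound 1 to compound 3.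

Compound 4 `COc1cc2c(Oc3ccc(NC(=O)c4cn(-c5cc(C)ccc5C)cn4)cc3F)ccnc2cc1OCCCN1CCC(C)CC1` differs from compound 2 by a single change: 4-methylpiperidin-1-yl in place of 4-methylpiperazin-1-yl on a saturated chain carbon, three bonds along the chain from an oxygen on an aromatic ring. Among the compounds with values here, none of the measured steps touches this part of the molecule; all three steps vary the aryl group on the aromatic nitrogen and leave the 4-methylpiperazin-1-yl tail unchanged. Within the data shown here, there is therefore no measured step that bears directly on the change from compound 2 to compound 4, and the expectation rests on the change being remote from the part where the measured steps act. On that basis a step no larger than the scatter is expected, in either direction, with a slight lean toward a higher number. For compound 4 the estimated value in this assay is 900 nM, between 350 nM and 2500 nM, which would be an expected step of a 1.4-fold higher number from compound 2 to compound 4 (0.14 log units; within the scatter).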

Compound 4, half-maximal inhibitory concentration: 5650 nM
Estimate against measurement, compound 4: 6.3-fold (0.80 log units) below, outside the stated range (above it).
By their numbers in this assay, from the lowest: compound 1; then compound 2; then compounds 3 and 4 (each within the scatter of the next).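

In this assay, the end of the chain proves to be no silent part of the molecule: 4-methylpiperidin-1-yl in place of 4-methylpiperazin-1-yl gives an 8.7-fold higher number from compound 2 to compound 4 (0.94 log units; beyond the scatter), a step beyond the scatter. Within the data shown here, the two groups have the same number of heavy atoms and differ by one ring nitrogen exchanged for carbon, so a single-atom change at this position is enough to shift the read-out, something the earlier compounds, which vary only the aryl group on the aromatic nitrogen, could not show. Nothing available here accounts for this step.

The compounds shown leave open whether the same step would appear with the 2-methoxyphenyl group of compound 1. They also leave open how a morpholin-4-yl group, a dimethylamino group or a longer chain would read at this position.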